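The source may hold more compounds than are shown below. What is called first, only, known or untested is meant among the compounds shown, and "the series" means these compounds.

Measured compounds in this series:
- compound 1 `CCOc1nc(C)nc2sc(-c3ccccc3)nc12`: 11%
- compound 2 `CCOc1nc(C)nc2sc(-c3ccc(C)cc3)nc12`: 1%

In an assay on CHO cells for displacement of a labelled ligand from adenosine receptor A1 (Homo sapiens), read by scintillation counting, with a stated time of 120 min, tested at 1 uM (a higher number here means more inhibition at the concentration tested (going by the name of the read-out), a lower number less inhibition), compound 1 gives 11% and compound 2 gives 1%. On these two numbers compound 2 has the lowest value; its nearest neighbour is compound 1, and the step of a number 10 percentage points lower from compound 1 to compound 2 (within the scatter) is within the scatter, so the two cannot be told apart.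

Compound 3 `CCOc1nc(C)nc2sc(-c3ccc(Cl)cc3)nc12` is the next member: chloro in place of methyl on an aromatic carbon. Within the data shown here, the only measured step, a number 10 percentage points lower from compound 1 to compound 2 (within the scatter), is the exchange of hydrogen for methyl at this same place and stayed within the scatter; no measured step exchanges methyl for chloro, so nothing in the data points to a shift beyond the scatter. The expected step for compound 3 is therefore a number 7 percentage points higher from compound 2 to compound 3 (within the scatter). Compound 3 is estimated at 8%, with a range from -8% to 25%.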

Compound 3, a percentage reported as inhibition, at one concentration (the size of the read-out at that concentration, not a potency): 6%
The estimate for compound 3 lay 2 percentage points above the measured number; low and high end bracket the measured number.
By their numbers in this assay, from the lowest: compounds 2, 3 and 1 (each within the scatter of the next).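

On the six-membered aromatic ring of carbon only, para to a large group, chloro now stands alongside hydrogen and methyl: in this assay the exchange for methyl gives a number 5 percentage points higher from compound 2 to compound 3 (within the scatter) and the exchange for hydrogen gives a number 5 percentage points lower from compound 1 to compound 3 (within the scatter) at this same place. Neither step separates chloro from the other two groups, so this position has now taken a halogen as well as a carbon substituent without a readable shift in the inhibition. No measurement is at hand that bears on why these numbers lie so close together.

Going by these compounds, what an amine, a carboxylic acid, a methoxy group or a longer chain would do at this place stays open. So does whether changes elsewhere on the shared core would move the inhibition beyond the scatter.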